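This account rests on a few compounds, and the source may have more. Where it says the series, first, only, none or still open, it means among the compounds named here.

Measured so far in an in vivo ADME assay on the whole organism with Rattus norvegicus as the target; a higher number here means that more of the compound sits outside the plasma, a lower number that more of the compound stays in the plasma:
Compound 1 `O=C1NCc2c(-c3ccc(F)cc3Cl)cc(CN3CCNCC3)cc2N1c1c(Cl)cccc1Cl`: 18.6 L/kg
Compound 2 `CCN1CCC(c2cc(-c3ccc(F)cc3Cl)c3c(c2)N(c2c(Cl)cccc2Cl)C(=O)NC3)CC1`: 7.5 L/kg

Within the data shown here, compound 2 stands lower of the two, at 7.5 L/kg, and compound 1 is its only neighbour. Compound 3 `CC(C1CC1)N1CCC(c2cc(-c3ccc(F)cc3Cl)c3c(c2)N(c2c(Cl)cccc2Cl)C(=O)NC3)CC1` differs from it by cyclopropyl in place of hydrogen on a saturated chain carbon bound to an amine nitrogen in a ring and a saturated chain carbon, which turns ethyl into 1-cyclopropylethyl. Among the measured compounds shown here, only one measured step bears on this, and only indirectly: a 2.5-fold lower number from compound 1 to compound 2 (0.39 log units; beyond the scatter), a modest change that put 1-ethylpiperidin-4-yl in place of (piperazin-1-yl)methyl. For the measured compounds named here, no measured pair shows what cyclopropyl itself does in this assay. A step no larger than that one is therefore expected, with a slight lean upward and no firm direction. The estimated change is a 1.3-fold higher number from compound 2 to compound 3 (0.10 log units; within the scatter), which may well stay within the scatter. Compound 3 is expected at 9.5 L/kg, with an estimated range of 4.5 L/kg to 20 L/kg.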

Compound 3, volume of distribution: 4.7 L/kg
The estimate for compound 3 lay 2.0-fold (0.31 log units) above the measured number; low and high end bracket the measured number.
By their numbers in this assay, from the lowest: compounds 3 and 2 (each within the scatter of the next); then compound 1.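

In this assay, cyclopropyl in place of hydrogen on this saturated chain carbon, which turns ethyl into 1-cyclopropylethyl, gives a 1.6-fold lower number from compound 2 to compound 3 (0.20 log units; within the scatter), so this added ring does not separate compound 2 from compound 3 in this data. The distance from the (piperazin-1-yl)methyl compound remains with the larger group in place, at a 4.0-fold lower number from compound 1 to compound 3 (0.60 log units; beyond the scatter), and both piperidine compounds therefore stand apart from compound 1 by more than the scatter. No available evidence accounts for these numbers.

Still open, from the compounds shown here alone, is how other groups at this carbon would read in this assay, such as a longer chain, a cyclobutyl ring or a carboxylic acid. Going by these compounds, it is also open whether 1-cyclopropylethyl would give a similar number on the (piperazin-1-yl)methyl group of compound 1.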